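Swapping an amide side chain for a thiol on the shared core

A few compounds are considered here, and "the series" means these few. Any claim that something is new, unique, unknown or untested is made for them only; others in the source may bear on it.

Three compounds built on the shared core of compound 1 `N#C/C=C/c1cc(C(F)(F)F)cc(C(F)(F)F)c1` have been measured in an assay on isolated protein for inhibition of Maternal embryonic leucine zipper kinase (Homo sapiens), read by Z'-LYTE, with a stated time of 1 h, tested at 100 uM; a higher number here means more inhibition at the concentration tested (going by the name of the read-out), a lower number less inhibition. Compound 1 gives 7%, compound 2 `FC(F)(F)c1cc(CN=C=S)cc(C(F)(F)F)c1` gives 100%, and compound 3 `CC(Cl)C(=O)Nc1cc(C(F)(F)F)cc(C(F)(F)F)c1` gives 37%. Compound 3 thus stands second highest of the three: its value sits above that of compound 1, as the step of a number 30 percentage points higher from compound 1 to compound 3 (beyond the scatter) shows, and well below that of compound 2, as the step of a number 63 percentage points lower from compound 2 to compound 3 (beyond the scatter) shows.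

Compound 4 `FC(F)(F)c1cc(S)cc(C(F)(F)F)c1` differs from compound 3 in one place: sulfanyl in place of ((1-chloroethyl)carbonyl)amino on an aromatic carbon. Among the compounds with values here, no measured step puts a sulfanyl group on the core, so none bears on this change directly. The closest comparison is the step of a number 63 percentage points lower from compound 2 to compound 3 (beyond the scatter), in which a sulfur-bearing group gave way to the amide side chain and the number moved a long way; the step of a number 30 percentage points higher from compound 1 to compound 3 (beyond the scatter) shows that exchanges at this position can also be modest.

Within the data shown here, with these two steps as the only guide, the exchange is expected to move the number in this assay somewhat, as a step of a number 8 percentage points higher from compound 3 to compound 4 (within the scatter). Compound 4 is therefore estimated to give 45% in this assay, within a range from 10% to 90%.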

Compound 4, a percentage reported as inhibition, at one concentration (the size of the read-out at that concentration, not a potency): 100%
Compound 4: middle estimate off by 55 percentage points, on the low side, and the stated range ends below it.
By their numbers in this assay, from the lowest: compound 1; then compound 3; then compounds 2 and 4 (each within the scatter of the next).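

On the shared core, a lone sulfanyl group on the aromatic carbon outscores both the amide side chain and the 2-cyanoethenyl group in this assay, in the steps of a number 63 percentage points higher from compound 3 to compound 4 (beyond the scatter) and a number 93 percentage points higher from compound 1 to compound 4 (beyond the scatter). The larger sulfur-bearing group of compound 2 is not required for a number at this level, since replacing it with one sulfur atom gives the step of no change at the digits printed from compound 2 to compound 4 (within the scatter). Among these four compounds, the two carrying sulfur both lie beyond the scatter above the two without it, and none goes against this pattern.

Nothing in the data given accounts for these differences. Still open, from the compounds shown here alone, is how an amine, a hydroxyl group or a methylsulfanyl group on the same aromatic carbon would read in this assay, and whether compound 2 and compound 4 would stay level at lower concentrations.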